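A Slightly Larger Side Group on a Shared Core

This account rests on a few compounds, and the source may have more. Where it says the series, first, only, none or still open, it means among the compounds named here.

In a functional assay on MDA-MB-231 cells (Homo sapiens) for antiproliferative activity, read by sulforhodamine B assay, with a stated time of 72 h (on this read-out lower numbers stand for stronger inhibition and higher numbers for weaker inhibition), compound 1 (`CC(=O)Nc1ccc(S(=O)(=O)Nc2cc(SCC(=O)N[C@@H](CC(C)C)B(O)O)c(O)c3ccccc23)cc1`) gives 4450 nM and compound 2 (`CC(C)C[C@H](NC(=O)CCSc1cc(NS(=O)(=O)c2ccccc2)c2ccccc2c1O)B(O)O`) gives 4200 nM in the same read-out. Compound 1 stands level with compound 2 on these numbers: the two lie within the usual scatter of repeated measurements and cannot be ranked. Compound 3 (`CC(=O)Nc1ccc(S(=O)(=O)Nc2cc(SCCC(=O)N[C@@H](CC(C)C)B(O)O)c(O)c3ccccc23)cc1`) has no number yet. It differs from compound 1 in a single place (a group of 12 heavy atoms (7 carbon, 1 boron, 1 nitrogen, 3 oxygen; no ring) in place of a group of 11 heavy atoms (6 carbon, 1 boron, 1 nitrogen, 3 oxygen; no ring), on a saturated chain carbon bound to a sulfur) and otherwise keeps the same core. For the measured compounds named here, no measured pair shows a change of this kind, so the data hold no direct precedent for its size. What they do hold is a narrow spread, with compound 1 at 4450 nM and compound 2 at 4200 nM showing no separation beyond the scatter. On that basis no shift beyond the scatter is expected in this assay in either direction. The expected change is small (a 1.1-fold lower number from compound 1 to compound 3 (0.05 log units; within the scatter)) and these data cannot settle its direction. For compound 3 the estimated value is 4000 nM with an expected range of 1800 nM to 9000 nM for that read-out.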

Compound 3, half-maximal inhibitory concentration: 2120 nM
For compound 3 the middle estimate is 1.9-fold (0.28 log units) above the measured one, and the stated range covers the measured number.
By their numbers in this assay, from the lowest: compounds 3, 2 and 1 (each within the scatter of the next, the first and the last beyond it).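

In this assay, for the compounds shown here, the group of 12 heavy atoms in place of the group of 11 heavy atoms, on a saturated chain carbon bound to a sulfur, gives a 2.1-fold lower number from compound 1 to compound 3 (0.32 log units; beyond the scatter); this modest step is the first evidence that a change at this position can carry the number beyond the scatter, which the earlier pair of compounds could not show. The acetamido group on an aromatic carbon, set against hydrogen with the group of 12 heavy atoms in place on both sides, gives a 2.0-fold lower number from compound 2 to compound 3 (0.30 log units; within the scatter), so that change cannot be read as having any effect on the number in this read-out. No measurement at hand accounts for the step at the chain, and the result stands here as an observation without an explanation.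

As far as these compounds go, whether the number keeps dropping with a longer chain at this position, or what an amine or a carboxylic acid on that chain would do, remains open. The compounds shown also hold no counterpart of compound 2 carrying the group of 11 heavy atoms, so it is unknown whether the step at the chain holds without the acetamido group.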